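The source may hold more compounds than are shown below. What is called first, only, known or untested is meant among the compounds shown, and "the series" means these compounds.

Working notes on the series. In an assay for displacement of a labelled ligand from corticotropin-releasing factor receptor 1 (Homo sapiens) (on this read-out higher numbers stand for weaker inhibition and lower numbers for stronger inhibition), compound 3 `CCCN(Cc1sc(Nc2c(C)cc(Cl)cc2Cl)nc1C(F)(F)F)CC1CC1` gives 16 nM, the lowest of the three values recorded. The two other measured compounds carry amide-type cores rather than the benzylamine-type linkage of compound 3: compound 1 `CCN(CC)C(=O)c1sc(Nc2c(Cl)cc(Cl)cc2Cl)nc1C` gives 5000 nM in this assay, and compound 2 `CCCN(CC1CC1)C(=O)c1sc(Nc2c(Cl)cc(Cl)cc2Cl)nc1CC` gives 11000 nM. Both gaps to compound 3 lie well beyond the scatter, and as neither pair differs in only one place, nothing more is drawn from them than the values themselves.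

Compound 4 `CCCN(Cc1sc(Nc2c(Br)cc(Br)cc2Br)nc1C(F)(F)F)CC1CC1` has not been measured. It differs from compound 3 in one place: 2,4,6-tribromophenyl in place of 2,4-dichloro-6-methylphenyl on a nitrogen on an aromatic ring. Nothing in the measured set isolates a change of the aryl substituents on that nitrogen, so the expectation rests on compound 3 alone. The size of the step is expected to be small, with no clear direction beyond the scatter, leaning if anything toward a slightly higher number; the expected step from compound 3 to compound 4 is a 1.6-fold higher number from compound 3 to compound 4 (0.19 log units; within the scatter). On that basis compound 4 is estimated to give 25 nM in this assay, with a range of 8 nM to 80 nM.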

Compound 4, inhibition constant: 7.8 nM
For compound 4 the middle estimate is 3.2-fold (0.51 log units) above the measured one, and the stated range ends above it.
By their numbers in this assay, from the lowest: compound 4; then compound 3; then compound 1; then compound 2.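

Going by these compounds alone, at the aryl group on a nitrogen on an aromatic ring, the first isolated change, 2,4,6-tribromophenyl in place of 2,4-dichloro-6-methylphenyl gives in this assay a 2.1-fold lower number from compound 3 to compound 4 (0.31 log units; beyond the scatter) and so marks a modest gain that only just clears the usual scatter. The position therefore accepts an exchange of one methyl and two chlorine atoms for three bromine atoms without loss of binding, while the heavy-atom count of the group stays at 9 and neither group carries hydrogen-bond donors or acceptors. No measurement available here bears on the origin of this step.

From the compounds shown here alone, all three substituents on the aryl ring change together, so the step cannot be assigned to any one of them, and it remains open whether 2,4-dibromo-6-methylphenyl would give a number nearer compound 3 or compound 4, or how a methoxy group on this ring would fare. The amide-type compound 1 and compound 2 differ from the others in more than one place, so the contribution of the linkage and of the trifluoromethyl group also remains unresolved.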